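The source may hold more compounds than are shown below. What is called first, only, known or untested is meant among the compounds shown, and "the series" means these compounds.

Compound 1 `O=C(Nc1cc(-c2ccccc2)[nH]n1)c1cccnc1F` gives 14600 nM in a functional assay on WM1361 cells (Homo sapiens) for antiproliferative activity, read by MTT assay, with a stated time of 48 h (on this read-out higher numbers stand for weaker inhibition and lower numbers for stronger inhibition), and holds the lower of the two numbers in hand, though compound 2 `O=C(Nc1cc(-c2ccccc2)[nH]n1)c1cncc(Br)c1`, which gives 19300 nM, sits within the scatter of it: the step of a 1.3-fold higher number from compound 1 to compound 2 (0.12 log units; within the scatter) is not a real difference. Compound 3 `Cc1ccc(-c2cc(NC(=O)c3cccnc3F)n[nH]2)cc1` differs from compound 1 by methyl in place of hydrogen on an aromatic carbon. Going by the values given here, no measured pair touches that place. Among the compounds with values here, the only recorded step, a 1.3-fold higher number from compound 1 to compound 2 (0.12 log units; within the scatter), exchanges the group on the carbonyl carbon and so says nothing about this change. Within the data shown here, with no bearing step, compound 3 is expected to show no shift beyond the scatter in this assay, and the step of a 1.0-fold lower number from compound 1 to compound 3 (0.02 log units; within the scatter) is estimated on that basis. Compound 3 is therefore expected to give about 14000 nM in this assay, within a range of 5000 nM to 40000 nM.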

Compound 3, half-maximal inhibitory concentration: 13300 nM
Compound 3: the middle estimate sits 1.1-fold (0.02 log units) above what was measured, within the range that was stated.
By their numbers in this assay, from the lowest: compounds 3, 1 and 2 (each within the scatter of the next).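

Going by these compounds alone, with the 2-fluoropyridin-3-yl group held fixed, the change from phenyl to 4-methylphenyl gives the first reading at this position in this assay. The step of a 1.1-fold lower number from compound 1 to compound 3 (0.04 log units; within the scatter) shows that methyl in place of hydrogen on this aromatic carbon, para to a large group, produces no difference that can be told from the scatter. Nothing in hand gives a reason for this result.

A single methyl does not settle the position: an amine, a carboxylic acid or a longer chain such as n-butyl on the same carbon could still move the number beyond the scatter. From the compounds shown here alone, it also remains open whether methyl leaves the number just as undisturbed when the 5-bromopyridin-3-yl group of compound 2 sits on the carbonyl carbon.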